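The source may hold more compounds than are shown below. What is called first, only, known or untested is meant among the compounds shown, and "the series" means these compounds.

Measured so far:
compound 1 `CC1CCN(c2nc(C(F)(F)Cl)ccc2CNC(=O)C(C)c2ccc(NS(C)(=O)=O)c(F)c2)CC1` — 0.3 nM
compound 2 `CC1CCN(c2nc(C3CC3)ccc2CNC(=O)C(C)c2ccc(NS(C)(=O)=O)c(F)c2)CC1` — 0.9 nM

Of the compounds shown here, two have been tested in an assay on CHO cells for antagonist activity at transient receptor potential cation channel subfamily V member 1 (Homo sapiens), read by FLIPR; a lower number here means a stronger inhibitor, a higher number a weaker inhibitor. Compound 1 gives 0.3 nM, the lower of the two numbers, and compound 2 gives 0.9 nM. Among the compounds with values here, the one measured step, a 3.0-fold higher number from compound 1 to compound 2 (0.48 log units; beyond the scatter), concerns the chloro(difluoro)methyl group and leaves the rest of the molecule unchanged.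

Compound 3 `CC1CC(C)CN(c2nc(C(F)(F)Cl)ccc2CNC(=O)C(C)c2ccc(NS(C)(=O)=O)c(F)c2)C1` keeps the chloro(difluoro)methyl group of compound 1 and alters the saturated ring instead: 3,5-dimethylpiperidin-1-yl in place of 4-methylpiperidin-1-yl on an aromatic carbon. Within the data shown here, no measured step touches this ring, so nothing here shows how this assay responds to a change at that place. Among the measured compounds shown here, the only comparison available, from compound 1 to compound 2, sits elsewhere and was modest. With no direct guide, the expectation is a number close to that of compound 1, with a change no larger than the usual scatter in either direction. For compound 3 in this assay the estimate is 0.4 nM, within 0.15 nM to 1.2 nM. This expected step, a 1.3-fold higher number from compound 1 to compound 3 (0.12 log units; within the scatter), is small.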

Compound 3, inhibition constant: 1 nM
The estimate for compound 3 lay 2.5-fold (0.40 log units) below the measured number; measured number inside the range.
By their numbers in this assay, from the lowest: compound 1; then compounds 2 and 3 (each within the scatter of the next).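

Within the data shown here, this is the first change to the saturated ring on the shared core, and in this assay that place responds: 3,5-dimethylpiperidin-1-yl in place of 4-methylpiperidin-1-yl gives a 3.3-fold higher number from compound 1 to compound 3 (0.52 log units; beyond the scatter). The step is modest, and compound 3 remains a strong inhibitor at 1 nM, so this position accepts the extra methyl group at only a limited cost. Nothing available offers a reason for this step.

The compounds shown do not separate moving the methyl group from adding a second one, a question that 3-methylpiperidin-1-yl could address. They also leave open how an unsubstituted piperidine, a morpholine ring or an open-chain amine such as diethylamino would behave at this position.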